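A few compounds are considered here, and "the series" means these few. Any claim that something is new, unique, unknown or untested is made for them only; others in the source may bear on it.

Compound 1, `CCN(CC)CCCN(CCCN(CC)CC)/C(C)=N\c1ccnc2cc(Cl)ccc12`, and compound 2, `CCN(CC)CCCN/C(=N\c1ccnc2cc(Cl)ccc12)c1ccccc1`, were both run in an ADME assay (liver) for metabolic stability, with Liver microsome (Homo sapiens) as the target, read by LC-MS, using microsomes, tested at 1 uM; on this read-out higher numbers stand for a longer-lived compound and lower numbers for a shorter-lived compound. Compound 1 gives > 1 h in this assay, a limit of the assay rather than a number, as noted in the limit of > 1 h in this assay, at which 1 of the 2 values shown sits. Within the data shown here, compound 2 gives 0.35 h in this assay, the only number among the values shown. Compound 3, `CCN(CC)CCCN/C(=N\c1ccnc2cc(Cl)ccc12)c1cccnc1`, carries pyridin-3-yl in place of phenyl on a carbon with a double bond to nitrogen. In this assay the step of a 1.4-fold higher number from compound 2 to compound 3 (0.15 log units; within the scatter) is expected to be small, no larger than the usual scatter, with a slight lean toward a longer-lived compound. Compound 3 is therefore estimated at 0.5 h, between 0.25 h and 1 h.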

Compound 3, half-life: 0.6 h
Compound 3: middle estimate off by 1.2-fold (0.08 log units), on the low side; the range from low to high includes it.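

In this assay, pyridin-3-yl in place of phenyl on a carbon with a double bond to nitrogen gives a 1.7-fold higher number from compound 2 to compound 3 (0.23 log units; within the scatter). This position therefore accepts a ring nitrogen, and with it one hydrogen-bond acceptor, with the two values remaining within the scatter of each other. Nothing among the data shown explains the step. Going by these compounds, whether pyridin-2-yl, pyridin-4-yl or a phenyl carrying fluorine or a methoxy group would read the same at this position stays open.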